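Pyridin-2-yl replacing 4-aminophenyl in a cytotoxicity series

The source may report more compounds than this note shows. Statements on the series, on what has been measured and on what is new or still open speak of the compounds shown alone.

Compound 1 `COc1ccc([C@H]2CC(=O)N(c3ccc(C)c(N)c3)C2)cc1OC1CCCC1` in a functional assay on HEK293 cells (Homo sapiens) for cytotoxicity (a higher number here means that more compound is tolerated, a lower number that less compound is tolerated), gives > 10000 nM, which is a limit of this assay.
Compound 2 `COc1ccc([C@H]2CC(=O)N(c3ccc(N)cc3)C2)cc1OC1CCCC1` in this assay gives > 10000 nM, again a limit.
Compound 3 `COc1ccc([C@H]2CC(=O)N(c3cccc(C#N)c3)C2)cc1OC1CCCC1` in this assay gives > 10000 nM, also a limit.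

Compound 2 therefore stands at a limit, not at a number, and so do the two other values. Compound 4 `COc1ccc([C@H]2CC(=O)N(c3ccccn3)C2)cc1OC1CCCC1` differs from compound 2 as follows: pyridin-2-yl in place of 4-aminophenyl on an amide-type nitrogen in a ring. The measured steps a step that the two limits leave unreadable from compound 1 to compound 2, a step that the two limits leave unreadable from compound 1 to compound 3 and a step that the two limits leave unreadable from compound 2 to compound 3 cannot be sized, because of the limit of > 10000 nM in this assay, at which 3 of the 3 values shown sit. No direction can be read from them. Compound 4 is therefore expected to sit near the same limit, with an estimated step that the limit leaves unreadable from compound 2 to compound 4. The estimate for compound 4 is 12000 nM, ranging from 5000 nM to 30000 nM.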

Compound 4, half-maximal cytotoxic concentration: > 10000 nM
Compound 4: no number, only a limit; the forecaster's own chance of this, stated with the estimate: 80%; the middle value is on the limit's open side.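

In this assay, for the compounds shown here, compound 4 gives > 10000 nM, which is a limit, so no step between compound 4 and compound 1, compound 2 or compound 3 can be read. The compounds shown leave open whether the four differ in cytotoxicity at all.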